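Dimethylamino for acetyl on the pendant phenyl

The compounds below may be only part of what the source reports. "The series", "measured", "known", "first", "only" and "open" are said of these compounds alone.

Measured so far:
compound 1 `COc1cc(C)cc(-c2c(-c3ccnc(-c4ccc(C(C)=O)cc4)c3)cnn2CC#N)c1` — > 100000 nM
compound 2 `COc1cc(C)cc(-c2nn(CC#N)cc2-c2ccc(-c3cccc(C(C)=O)c3)nc2)c1` — > 100000 nM
compound 3 `Cc1cc(O)cc(-c2nn(CC#N)cc2-c2ccnc(-c3ccc(Oc4ccccc4)cc3)c2)c1` — 6020 nM

In a functional assay on K562 cells (Homo sapiens) for inhibition, read by sulforhodamine B assay, with a stated time of 48 h (on this read-out lower numbers stand for stronger inhibition of growth and higher numbers for weaker inhibition of growth), compound 1 gives > 100000 nM, which is a limit of the assay and not a number. Compound 2 also gives > 100000 nM, again a limit. Compound 3 gives 6020 nM. Compound 1 therefore stands at the limit of > 100000 nM in this assay, at which 2 of the 3 values shown sit, and no number is known for it, only that it lies beyond the range measured.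

Compound 4 `COc1cc(C)cc(-c2c(-c3ccnc(-c4ccc(N(C)C)cc4)c3)cnn2CC#N)c1` differs from compound 1 by dimethylamino in place of acetyl on an aromatic carbon. Going by the values given here, no pair of measured compounds differs in one place, so no measured step bears on this change, and compound 3 differs from compound 1 in more than one place. Because compound 1 gives only the limit > 100000 nM in this assay, any step to compound 4 can only be a move down from that limit or none at all. For compound 4 the expected step is an at least 1.6-fold lower number from compound 1 to compound 4 (0.22 log units; that floor lies within the scatter), with a fair chance that the assay again reports only a limit. Compound 4 is estimated at 60000 nM, between 15000 nM and 200000 nM.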

Compound 4, concentration for total growth inhibition: 3820 nM
Estimate against measurement, compound 4: 16-fold (1.20 log units) above; the measured number lies below the stated range.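

Setting dimethylamino in place of acetyl, para to a large group on the six-membered aromatic ring of carbon only, gives in this assay an at least 26-fold lower number from compound 1 to compound 4 (1.41 log units; beyond the scatter), the first single-place step available in this series. This position is therefore not indifferent to the group it carries, even though both groups have the same count of heavy atoms and of hydrogen-bond acceptors. The full size of the step cannot be fixed because compound 1 gives only a limit of the assay: the limit of > 100000 nM in this assay, at which 2 of the 4 values shown sit.

Going by these compounds, it remains open whether the gain is specific to dimethylamino or would also appear with a primary amine, a methoxy group or a morpholine at this place. Also open, on these data alone, is whether the same replacement would lower the number for compound 2, which carries acetyl too.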